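The source may hold more compounds than are shown below. What is called first, only, known or untested is meant among the compounds shown, and "the series" means these compounds.

Compound 1 `O=C(O)Cc1sc(C(c2ccccc2)c2ccccc2)nc1-c1ccccc1` holds the higher of the two numbers in hand: in an in vitro assay on HEK385-7 cells for displacement of a labelled ligand from prostaglandin D2 receptor 2 (Homo sapiens) (on this read-out higher numbers stand for weaker inhibition and lower numbers for stronger inhibition), compound 1 gives 570 nM. Its only measured companion, compound 2 `O=C(O)Cc1sc(C(c2ccc(F)cc2)c2ccc(F)cc2)nc1-c1ccccc1`, gives 16 nM in this assay, and the gap between the two lies beyond the scatter. Compound 3 `COc1ccc(OC)c(-c2nc(C(c3ccccc3)c3ccccc3)sc2CC(=O)O)c1` differs from compound 1 by 2,5-dimethoxyphenyl in place of phenyl on an aromatic carbon of the five-membered aromatic ring with 1 nitrogen and 1 sulfur, next to the ring nitrogen. Within the data shown here, no measured pair shows this change, so its size is open and must be guessed. A modest gain is expected, with the step from compound 1 to compound 3 estimated as a 1.9-fold lower number from compound 1 to compound 3 (0.28 log units; within the scatter), while a step within the scatter would not surprise. For compound 3 in this assay the expected value is 300 nM, with a range from 60 nM to 1500 nM.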

Compound 3, half-maximal inhibitory concentration: > 105 nM
Compound 3: only a limit was reported; the forecaster's own chance of this, stated with the estimate: 5%; the middle value is on the limit's open side.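

Among these compounds, for compound 3 the reported > 105 nM is a limit and not a number, so no step from compound 1 to compound 3 can be read. The compounds shown leave open how far, and in which direction, 2,5-dimethoxyphenyl in place of phenyl on an aromatic carbon moves the number.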